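Shortening the imidazole-bearing chain of compound 3 by one carbon

This account rests on a few compounds, and the source may have more. Where it says the series, first, only, none or still open, it means among the compounds named here.

Compound 3 `O=C(NCCCCCCn1ccnc1)c1ccc(Cl)s1` was tested in an assay on isolated protein for inhibition of Thromboxane-A synthase (Rattus norvegicus) (a higher number here means a weaker inhibitor, a lower number a stronger inhibitor), where compound 3 gives 200 nM. Among the three compounds measured so far, that places compound 3 second highest: compound 2 `O=C(NCCCCCCCCn1ccnc1)c1cc2cc(Cl)ccc2[nH]1` gives a lower number, 27 nM, and the gap between them lies beyond the scatter, while compound 1 `O=C(NCCCCn1ccnc1)c1ccc(Cl)nc1` gives a higher number, 8000 nM, with a gap that also lies beyond the scatter. Compound 1, compound 2 and compound 3 differ from one another in both the aromatic core and the chain, so none of these gaps can be tied to one change alone.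

Compound 4 `O=C(NCCCCCn1ccnc1)c1ccc(Cl)s1` keeps the core of compound 3 and differs only in the chain: 1H-imidazol-1-yl in place of (1H-imidazol-1-yl)methyl on a saturated chain carbon, five bonds along the chain from an amide-type nitrogen. Among the measured compounds shown here, no measured pair shows this chain change on its own. Compared with compound 3, a small rise in number is expected for compound 4, estimated as a 2.0-fold higher number from compound 3 to compound 4 (0.30 log units; within the scatter), which would still sit near the scatter. Compound 4 is therefore expected to give about 400 nM, within a range of 150 nM to 1500 nM.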

Compound 4, half-maximal inhibitory concentration: 200 nM
Compound 4: the middle estimate sits 2.0-fold (0.30 log units) above what was measured; low and high end bracket the measured number.
By their numbers in this assay, from the lowest: compound 2; then compounds 3 and 4 (each within the scatter of the next); then compound 1.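

Among the compounds shown here, replacing (1H-imidazol-1-yl)methyl with 1H-imidazol-1-yl on a saturated chain carbon, five bonds along the chain from an amide-type nitrogen, gives the first change in this assay that can be read on its own, with no change at the digits printed from compound 3 to compound 4 (within the scatter). The earlier compounds shown here could not show this, as they differ in both core and chain. On this core and over this one change, the chain can therefore be altered with no shift beyond the scatter, though no supporting data explain this result.

Going by these compounds, whether a longer chain on this core would also leave the number in place remains open, as does whether the same change would read alike on the core of compound 1 or compound 2. An amine or a carboxylic acid in place of the 1H-imidazol-1-yl is also untested among the compounds shown.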